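The source may hold more compounds than are shown below. What is called first, only, known or untested is meant among the compounds shown, and "the series" means these compounds.

Measured so far:
compound 1, `COc1ccc(-n2ccc(=O)c(C(=O)Nc3ccc(Oc4ccnc5[nH]ccc45)cc3)n2)cc1`, gives 53100 nM in a functional assay on A549 cells (Homo sapiens) for cytotoxicity, read by MTT assay, with a stated time of 72 h; on this read-out lower numbers stand for stronger inhibition and higher numbers for weaker inhibition.
compound 2, `O=C(Nc1ccc(Oc2ccnc3[nH]ccc23)cc1)c1nn(-c2ccc(Cl)c(C(F)(F)F)c2)ccc1=O`, gives 2190 nM in this assay.
compound 3, `COc1ccc(-n2ccc(=O)c(C(=O)Nc3ccc(Oc4ccnc5[nH]ccc45)c(F)c3)n2)cc1`, gives > 60000 nM in this assay, which is a limit of the assay and not a number.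

Within the data shown here, compound 3 therefore stands only as a floor in this assay; it is the one value here that sits at the limit of > 60000 nM in this assay, at which 1 of the 3 values shown sits. Its relation to compound 1 is the step of an at least 1.1-fold higher number from compound 1 to compound 3 (0.05 log units; that floor lies within the scatter), so the fluoro on the central ring on its own shows no resolved effect.

Compound 4, `O=C(Nc1ccc(Oc2ccnc3[nH]ccc23)c(F)c1)c1nn(-c2ccc(Cl)c(F)c2)ccc1=O`, is to be measured. It differs from compound 3 by 4-chloro-3-fluorophenyl in place of 4-methoxyphenyl on an aromatic nitrogen. The measured step that bears on this is a 24-fold lower number from compound 1 to compound 2 (1.38 log units; beyond the scatter), where 4-chloro-3-(trifluoromethyl)phenyl replaced the same 4-methoxyphenyl on the same aromatic nitrogen; compound 4 bears 4-chloro-3-fluorophenyl instead. A step in the same direction, a clear drop beyond the scatter, is expected, with the reservation that compound 3 is a limit and the true starting point is not known. The step of an at least 12-fold lower number from compound 3 to compound 4 (1.07 log units; beyond the scatter) is the expected size. Compound 4 is estimated at 5000 nM, with a likely range from 1500 nM to 20000 nM.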

Compound 4, half-maximal inhibitory concentration: 10300 nM
For compound 4 the middle estimate is 2.1-fold (0.31 log units) below the measured one, and the stated range covers the measured number.
By their numbers in this assay, from the lowest: compound 2; then compound 4; then compound 1. At a limit, above all of these: compound 3.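

In this assay, the replacement of 4-methoxyphenyl on the aromatic nitrogen also lowers the number on the fluoro-bearing core, giving an at least 5.8-fold lower number from compound 3 to compound 4 (0.76 log units; beyond the scatter). The trifluoromethyl group of compound 2 is therefore not required for a drop beyond the scatter at this position, as compound 4 with 4-chloro-3-fluorophenyl shows one as well, and the fluoro shared by compound 3 and compound 4 does not prevent it. The step can be read only as a floor, with its true size unknown, and compound 3 is the compound that stands as a limit: the limit of > 60000 nM in this assay, at which 1 of the 4 values shown sits.

Compound 2 and compound 4 differ in two places, so the compounds shown do not rank 4-chloro-3-(trifluoromethyl)phenyl against 4-chloro-3-fluorophenyl on a single core, nor do they separate the contributions of the chloro and the fluoro within the new group. Also open, from the compounds shown here alone, is how the series would read in this assay with an amine or a carboxylic acid in place of the chloro on this aryl group.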